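The compounds below may be only part of what the source reports. "The series", "measured", "known", "first", "only" and "open" are said of these compounds alone.

In a functional assay on a cell-free system (plasma, Oryctolagus cuniculus) for inhibition, with stated times of 5 min, 1 min and 6 min (a higher number here means a weaker inhibitor, a lower number a stronger inhibitor), compound 1 `CCOC(=O)c1c(C)nc(-c2cccc(C#N)c2)n1OCC(N)=O` gives > 30000 nM, which is a limit of the assay and not a number. For the measured compounds named here, compound 2 `CCOC(=O)c1c(C)nc(-c2cccc(C#N)c2)n1OCc1ccc(OC)cc1` gives 6830 nM, the only actual number so far. Compound 3 `CCOC(=O)c1c(C)nc(-c2cccc(C#N)c2)n1OCc1ccc(C(=O)OC)cc1` differs from it by methoxycarbonyl in place of methoxy on an aromatic carbon, para to a large group. Going by the values given here, the sole measured step, an at least 4.3-fold lower number from compound 1 to compound 2 (0.64 log units; beyond the scatter), put 4-methoxyphenyl in place of carbamoyl, so it bears only loosely on this change. The expected result is a 1.1-fold lower number from compound 2 to compound 3 (0.02 log units; within the scatter), with no shift beyond the scatter foreseen. For compound 3 the estimate is 6500 nM, within an expected range of 2200 nM to 20000 nM.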

Compound 3, half-maximal inhibitory concentration: 9470 nM
For compound 3 the middle estimate is 1.5-fold (0.16 log units) below the measured one, and the stated range covers the measured number.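

In this assay, methoxycarbonyl can stand on this aromatic carbon, para to a large group, in place of methoxy without a change beyond the scatter, with a 1.4-fold higher number from compound 2 to compound 3 (0.14 log units; within the scatter). The gain over carbamoyl therefore does not depend on methoxy, since 4-(methoxycarbonyl)phenyl also gives an at least 3.1-fold lower number from compound 1 to compound 3 (0.50 log units; beyond the scatter). The size of that step is open-ended, as compound 1 is held at a limit of the assay: the limit of > 30000 nM in this assay, at which 1 of the 3 values shown sits.

Going by these compounds, whether an amine or a carboxylic acid on this carbon would shift the number beyond the scatter remains open. So does the effect of a longer chain in the ester.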